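Nitroimidazooxazine ethers: Vero cytotoxicity across aryl substituents

The source may report more compounds than this note shows. Statements on the series, on what has been measured and on what is new or still open speak of the compounds shown alone.

Measured compounds:
compound 1, `COc1ccc(-c2cccc(CO[C@@H]3COc4nc([N+](=O)[O-])cn4C3)c2)cc1F` — > 128000 nM
compound 2, `O=[N+]([O-])c1cn2c(n1)OC[C@@H](OCc1csc(-c3ccc(C(F)(F)F)cc3)n1)C2` — > 128000 nM
compound 3, `Cn1c(CO[C@@H]2COc3nc([N+](=O)[O-])cn3C2)cnc1-c1ccc(C(F)(F)F)cc1` — > 128000 nM

In an ADME assay on Vero cells (Chlorocebus sabaeus) for cytotoxicity, with a stated time of 72 h (a lower number here means a stronger inhibitor, a higher number a weaker inhibitor), compound 1 sits at > 128000 nM, which is a limit of the assay and not a number. In this assay compound 2 likewise returns only a limit, > 128000 nM. Compound 3 also returns only a limit in this assay, > 128000 nM. Among the measured compounds shown here, no step between measured compounds can therefore be sized; all three values rest on (the limit of > 128000 nM in this assay, at which 3 of the 3 values shown sit), so compound 3 stands at the same limit as the others and is not separated from them.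

Compound 4, `Cn1c(CO[C@@H]2COc3nc([N+](=O)[O-])cn3C2)cnc1-c1ccc(C#N)cc1`, differs from compound 3 by cyano in place of trifluoromethyl on an aromatic carbon. With every measured value at the limit, the step expected from compound 3 to compound 4 in this assay, a step that the limit leaves unreadable from compound 3 to compound 4, is none beyond the scatter. For compound 4 the estimate in this assay is 150000 nM, within 60000 nM to 400000 nM, with the result most likely again reported as a limit.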

Compound 4, half-maximal inhibitory concentration: > 128000 nM
Compound 4: a limit, no number (the forecaster's own chance of this, stated with the estimate: 85%); the middle value is on the limit's open side.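

No step can be read between compound 3 and compound 4, since both values are limits and not numbers: the limit of > 128000 nM in this assay, at which 4 of the 4 values shown sit.

The compounds shown leave open whether any of them reaches a measurable half-maximal concentration in this assay, and whether cyano in place of trifluoromethyl changes it.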